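A few compounds are considered here, and "the series" means these few. Any claim that something is new, unique, unknown or untested is made for them only; others in the source may bear on it.

In a functional assay on NCI-H1975 cells (Homo sapiens) for antiproliferative activity, read by MTT assay, with a stated time of 72 h (on this read-out lower numbers stand for stronger inhibition and higher numbers for weaker inhibition), compound 1 `COc1cc2ncnc(Nc3ccc(F)c(Cl)c3)c2cc1OCCCCC(=O)Nc1ccc(S(N)(=O)=O)cc1` gives 35600 nM. Compound 2 `COc1cc2ncnc(Nc3ccc(F)cc3)c2cc1OCCCCC(=O)Nc1ccc(S(N)(=O)=O)cc1` reaches only a limit of the assay, > 40000 nM, not a number (the limit of > 40000 nM in this assay, at which 1 of the 3 values shown sits). Between them the change is chloro in place of hydrogen on an aromatic carbon, giving an at least 1.1-fold lower number from compound 2 to compound 1 (0.05 log units; that floor lies within the scatter). Compound 3 `NS(=O)(=O)c1ccc(NC(=S)Nc2ccc3ncnc(Nc4cccc(C(F)(F)F)c4)c3c2)cc1` gives 7590 nM, a lower number than compound 1 by a gap beyond the scatter; how its core differs from that of compound 2 is not broken down here. Compound 4 `NS(=O)(=O)c1ccc(NC(=S)Nc2ccc3ncnc(Nc4ccc(Cl)c(C(F)(F)F)c4)c3c2)cc1` is not yet measured; it differs from compound 3 by chloro in place of hydrogen on an aromatic carbon, the same kind of change as from compound 2 to compound 1, though here the entering chloro sits ortho to a trifluoromethyl group and para to a large group rather than ortho to a fluoro group and meta to a large group. Since the earlier step of an at least 1.1-fold lower number from compound 2 to compound 1 (0.05 log units; that floor lies within the scatter) was small, the expected step is a 1.3-fold lower number from compound 3 to compound 4 (0.10 log units; within the scatter). Compound 4 is estimated at 6000 nM, between 2000 nM and 20000 nM.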

Compound 4, half-maximal inhibitory concentration: 11800 nM
Estimate against measurement, compound 4: 2.0-fold (0.29 log units) below; measured number inside the range.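

In this assay chloro in place of hydrogen on an aromatic carbon gives a 1.6-fold higher number from compound 3 to compound 4 (0.19 log units; within the scatter) and so does not clearly separate these two compounds. Set beside the earlier case, the comparison reads: the same change on two cores in this assay, an at least 1.1-fold lower number (0.05 log units; that floor lies within the scatter) from compound 2 to compound 1 and a 1.6-fold higher number (0.19 log units; within the scatter) from compound 3 to compound 4; the limit leaves it open whether they differ. As far as these compounds go, compound 2 gives > 40000 nM which is a limit of the assay and not a number; the size of the earlier step therefore stays unknown, and the pair of steps shows neither that the change carries over from one core to the other nor that it behaves differently.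

Still open, from the compounds shown here alone, is whether bromo or a nitrile in place of the chloro would give a step beyond the scatter on either core. A third core carrying the same change would also be needed before any general rule could be drawn.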